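Chain extension in the sulfur series

The source may hold more compounds than are shown below. What is called first, only, known or untested is meant among the compounds shown, and "the series" means these compounds.

compound 1 `CCSC[C@H](NC(C)=O)C(=O)CCl` 99900 nM
compound 2 `CCCSC[C@H](NC(C)=O)C(=O)CCl` 8000 nM
compound 3 `CCCCCCSC[C@H](NC(C)=O)C(=O)CCl` 700 nM

In a functional assay on MOLT-3 cells (Homo sapiens) (a higher number here means a weaker inhibitor, a lower number a stronger inhibitor), compound 3 gives 700 nM, the lowest of the three numbers, and its distance from each of the other two lies beyond the scatter. Compound 4 `CCCCCCCCCCSC[C@H](NC(C)=O)C(=O)CCl` lengthens the same chain: butyl in place of hydrogen on a saturated chain carbon, six bonds along the chain from a sulfur.

Two single extensions of this chain bear on the change: a 12-fold lower number from compound 1 to compound 2 (1.10 log units; beyond the scatter) and an 11-fold lower number from compound 2 to compound 3 (1.06 log units; beyond the scatter). The combined change is a 140-fold lower number from compound 1 to compound 3 (2.15 log units; beyond the scatter). Going by the values given here, all are large and run in one direction, and no measured compound goes against this. The second extension added propyl rather than methyl, yet its step was of similar size, so the return per added length appears to shrink. Among the compounds with values here, no measured chain is as long as the one in compound 4, so a further, smaller fall is expected, with real uncertainty. The expected step is a 4.7-fold lower number from compound 3 to compound 4 (0.67 log units; beyond the scatter) in this assay. The estimate for compound 4 is 150 nM, with an expected range from 30 nM to 800 nM.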

Compound 4, half-maximal inhibitory concentration: 3400 nM
The estimate for compound 4 lay 23-fold (1.36 log units) below the measured number; measured number outside the range, above it.
By their numbers in this assay, from the lowest: compound 3; then compound 4; then compound 2; then compound 1.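

In this assay, added length on the sulfur chain stops paying: butyl in place of hydrogen on a saturated chain carbon, six bonds along the chain from a sulfur, gives a 4.9-fold higher number from compound 3 to compound 4 (0.69 log units; beyond the scatter), the reverse of the direction of the earlier extensions. The series is therefore not a steady fall with length, and compound 4 goes against that earlier pattern, although the longer chain still retains a 2.4-fold lower number from compound 2 to compound 4 (0.37 log units; beyond the scatter). Nothing available explains this reversal.

Still open, from the compounds shown here alone, is whether a heptyl or octyl chain on the sulfur would give a lower number than compound 3, so the best length remains unfixed. Also open, going by these compounds, is how a long chain carrying an amine or a carboxylic acid would read in this assay.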